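The source may hold more compounds than are shown below. What is called first, only, known or untested is meant among the compounds shown, and "the series" means these compounds.

Compound 1 is `COC(=O)c1sc2cc(-c3ccoc3)cnc2c1N`. In a functional assay on A-375 cells (Homo sapiens) for inhibition, read by sulforhodamine B assay, with a stated time of 48 h (on this read-out lower numbers stand for stronger inhibition of growth and higher numbers for weaker inhibition of growth), compound 1 gives > 120000 nM, which is a limit of the assay and not a number.
Compound 2 is `COC(=O)c1sc2cc(-c3cccnc3)cnc2c1N`. In this assay compound 2 gives > 112000 nM, which is likewise a limit of the assay.

Among the measured compounds shown here, because both values are limits, the one measured step, a step that the two limits leave unreadable from compound 1 to compound 2, has no readable size. Compound 2 therefore stands at a limit, with no number to place it against compound 1.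

Compound 3 is `COC(=O)c1sc2cc(-c3ccccc3N)cnc2c1N`. It differs from compound 2 by 2-aminophenyl in place of pyridin-3-yl on an aromatic carbon. For the measured compounds named here, no measured step bears on this change with a readable size: the only evidence is the limit of > 112000 nM in this assay, at which 1 of the 2 values shown sits, and (the limit of > 120000 nM in this assay, at which 1 of the 2 values shown sits), both limits. Nothing in the data points to a change in this assay beyond the scatter in either direction, and the expectation can only be carried over from the limit at which compound 2 sits. Compound 3 is estimated at 150000 nM, with a range from 30000 nM to 600000 nM. That estimate amounts to an expected step that the limit leaves unreadable from compound 2 to compound 3.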

Compound 3, concentration for 50% growth inhibition: 2500 nM
The estimate for compound 3 lay 60-fold (1.78 log units) above the measured number, and the stated range ends above it.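

Putting 2-aminophenyl on this aromatic carbon of the shared core gives an at least 44-fold lower number from compound 2 to compound 3 (1.65 log units; beyond the scatter) in this assay, and the same group in place of furan-3-yl gives an at least 48-fold lower number from compound 1 to compound 3 (1.68 log units; beyond the scatter). The position is therefore not indifferent to what it carries: a measurable growth inhibition appears here with one group, whereas the two earlier groups gave only limits, and the step between those two still cannot be read. Both new steps give only a minimum size, because each starts from a limit, as with compound 2: the limit of > 112000 nM in this assay, at which 1 of the 3 values shown sits.

On these data alone, what remains open is whether the amino group or the ring of carbon only accounts for the change. A plain phenyl group would separate those two parts, and 2-hydroxyphenyl would show whether another group in that spot on the ring can take the amino group's place.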